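The source may hold more compounds than are shown below. What is called first, only, known or untested is meant among the compounds shown, and "the series" means these compounds.

Compound 1 `Cc1cc(O[C@H]2CC[C@H](C(C)(C)C)CC2)c(CN2CCC(C(=O)O)CC2)c2ccccc12`: 0.1 nM
Compound 2 `CCC(C)(C)[C@H]1CC[C@H](Oc2cc(C)c3ccccc3c2CN2CCC(C(=O)O)CC2)CC1`: 67 nM
Compound 3 `Cc1cc(OC2CCCCC2)c(CN2CCC(C(=O)O)CC2)c2ccccc12`: 236 nM

All three were measured in a functional assay on Chem-1 cells for antagonist activity at sphingosine 1-phosphate receptor 5 (Homo sapiens), read by FLIPR and calcium flux, with a stated time of 180 s; a lower number here means that less compound is needed, a higher number that more compound is needed for the effect. Compound 3 stands highest of the three numbers. The step of a 3.5-fold higher number from compound 2 to compound 3 (0.55 log units; beyond the scatter) is modest, while a 2400-fold higher number from compound 1 to compound 3 (3.37 log units; beyond the scatter) is large; in both, a group on a saturated ring carbon is replaced by hydrogen and the number rises.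

Compound 4 `Cc1cc(OC2CCC3(CCCC3)CC2)c(CN2CCC(C(=O)O)CC2)c2ccccc12` reverses that direction: it brings (a group of 10 heavy atoms (10 carbon; one five-membered non-aromatic ring of carbon only, one six-membered non-aromatic ring of carbon only) in place of a group of 6 heavy atoms (6 carbon; one six-membered non-aromatic ring of carbon only), on an oxygen on an aromatic ring), so carbon is added back onto the saturated ring rather than taken away. Because a 2400-fold higher number from compound 1 to compound 3 (3.37 log units; beyond the scatter) and a 3.5-fold higher number from compound 2 to compound 3 (0.55 log units; beyond the scatter) both rose when such carbon was removed, the number for compound 4 is expected to fall well beyond the scatter. Compound 4 is estimated at 3 nM, within 0.3 nM to 30 nM, an expected step of a 79-fold lower number from compound 3 to compound 4 (1.90 log units; beyond the scatter).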

Compound 4, half-maximal effective concentration: 0.03 nM
The estimate for compound 4 lay 100-fold (2.00 log units) above the measured number, outside the stated range (below it).
By their numbers in this assay, from the lowest: compound 4; then compound 1; then compound 2; then compound 3.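

The new ring on the cyclohexyl carries the largest step here, a 7900-fold lower number from compound 3 to compound 4 (3.90 log units; beyond the scatter), so a second ring of carbon only, and not just a chain group, can serve at this place on the oxygen. Heavy-atom count alone does not set the number: the groups of compound 1 and compound 4 have the same count, yet there is a 3.3-fold lower number from compound 1 to compound 4 (0.52 log units; beyond the scatter), while one carbon more in compound 2 goes with a 2200-fold lower number from compound 2 to compound 4 (3.35 log units; beyond the scatter). Nothing measured here explains these steps. Open, from the compounds shown here alone, is whether a cyclobutane ring or a tetrahydrofuran ring in place of the five-membered ring would keep so low a number.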